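The source may report more compounds than this note shows. Statements on the series, on what has been measured and on what is new or still open speak of the compounds shown alone.

In a functional assay on HepG2 cells (Homo sapiens) for antiproliferative activity, read by CCK-8 assay, with a stated time of 48 h (on this read-out lower numbers stand for stronger inhibition and higher numbers for weaker inhibition), compound 1 `COc1ccc(/C=C\c2cc(OC)c(OC)c(OC)c2)cc1OCc1ccc(C=O)cc1`, which carries a formyl group on an aromatic carbon, gives 800 nM. Compound 2 `COc1ccc(/C=C\c2cc(OC)c(OC)c(OC)c2)cc1OCc1ccc(CNCCN(C)C)cc1` gives 4400 nM, the higher and therefore weaker of the two numbers. Within the data shown here, the only measured step, a 5.5-fold higher number from compound 1 to compound 2 (0.74 log units; beyond the scatter), put ((2-(dimethylamino)ethyl)amino)methyl in place of that formyl, and it is modest in size but beyond the scatter. Compound 3 `COc1ccc(/C=C\c2cc(OC)c(OC)c(OC)c2)cc1OCc1ccc(CN[C@H](C(=O)O)[C@@H](C)O)cc1` keeps the shared core and changes only the chain on the amine nitrogen of compound 2: 1-carboxy-2-hydroxypropyl in place of 2-(dimethylamino)ethyl on an amine nitrogen. Among the measured compounds shown here, no measured step changes this chain alone, so the earlier step is only a loose guide to how far one substitution can move the numbers in this assay. It offers no firm direction, so no change beyond the scatter is expected, with wide uncertainty. The estimated change is a 1.1-fold higher number from compound 2 to compound 3 (0.06 log units; within the scatter). For compound 3 the estimated value is 5000 nM, with an expected range of 1200 nM to 20000 nM.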

Compound 3, half-maximal inhibitory concentration: > 10000 nM
Compound 3: no number, only a limit (the forecaster's own chance of this, stated with the estimate: 10%); middle value at least 2.0-fold (0.30 log units) from the limit.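

Changing only the chain on the amine nitrogen, with 1-carboxy-2-hydroxypropyl in place of 2-(dimethylamino)ethyl, gives an at least 2.2-fold higher number from compound 2 to compound 3 (0.35 log units; beyond the scatter) in this assay, so the result at this position depends on the chain itself and not only on the loss of the formyl. Among these compounds, measured against the formyl, the new group gives an at least 12-fold higher number from compound 1 to compound 3 (1.09 log units; beyond the scatter), a larger step than the one seen for compound 2. The value of compound 3 is a limit and not a number, so both new steps give only a smallest size: the limit of > 10000 nM in this assay, at which 1 of the 3 values shown sits.

The compounds shown leave open whether the carboxylic acid or the hydroxyl of the new chain counts for more. They also leave open what a simple methyl or a longer chain ending in a dimethylamino group would do on this amine nitrogen.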